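This account rests on a few compounds, and the source may have more. Where it says the series, first, only, none or still open, it means among the compounds named here.

Measured so far in a functional assay on HepG2 cells (Homo sapiens) for cytotoxicity, read by MTT assay, with a stated time of 72 h; on this read-out higher numbers stand for weaker inhibition and lower numbers for stronger inhibition:
compound 1 `COc1cc(/C=N/NC(=O)Nc2cc3c(Nc4ccc(F)c(Cl)c4)ncnc3cc2O[C@H]2CCOC2)cc(OC)c1OC` – 31200 nM
compound 2 `COc1cc2ncnc(Nc3ccc(F)c(Cl)c3)c2cc1NC(=O)N/N=C/c1ccc(F)cc1Cl` – 29200 nM

Compound 2 stands within the scatter of compound 1, so these two values set no order. Compound 3 `COc1cc2ncnc(Nc3ccc(F)c(Cl)c3)c2cc1NC(=O)N/N=C/c1cc(OC)c(OC)c(OC)c1` has 3,4,5-trimethoxyphenyl in place of the 2-chloro-4-fluorophenyl of compound 2, on a carbon with a double bond to nitrogen: 3,4,5-trimethoxyphenyl in place of 2-chloro-4-fluorophenyl on a carbon with a double bond to nitrogen. The same 3,4,5-trimethoxyphenyl is present in compound 1, at 31200 nM, though the rest of that structure differs. In this assay no step beyond the scatter is expected, and the estimated step is a 1.0-fold higher number from compound 2 to compound 3 (0.01 log units; within the scatter). For compound 3 the estimated value is 30000 nM, with an expected range from 14000 nM to 65000 nM.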

Compound 3, half-maximal inhibitory concentration: 30100 nM
Estimate against measurement, compound 3: 1.0-fold (0.00 log units) below, within the range that was stated.
By their numbers in this assay, from the lowest: compounds 2, 3 and 1 (each within the scatter of the next).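

In this assay, 3,4,5-trimethoxyphenyl in place of 2-chloro-4-fluorophenyl on a carbon with a double bond to nitrogen gives no separable change (a 1.0-fold higher number from compound 2 to compound 3 (0.01 log units; within the scatter)). Methyl in place of oxolan-3-yl on an oxygen on an aromatic ring likewise stays level (a 1.0-fold lower number from compound 1 to compound 3 (0.02 log units; within the scatter)), so the two changes that compounds 1 and 2 carried together are now read singly, and neither moves the number. No measurement on hand offers an explanation for this flatness. Open, on these data alone, is whether an amine or a carboxylic acid on the phenyl ring would shift the number beyond the scatter. As far as these compounds go, a longer chain on that oxygen remains equally open.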